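The source may report more compounds than this note shows. Statements on the series, on what has been measured and on what is new or still open speak of the compounds shown alone.

Measured compounds:
- Compound 1 `C=CCc1cc(-c2cccc([N+](=O)[O-])c2)ccc1O`: > 100000 nM (a limit of the assay, not a number)
- Compound 2 `C=CCc1cc(-c2cccc(SC)c2)ccc1O`: 66000 nM

Among the measured compounds shown here, in a functional assay on A549 cells (Homo sapiens) for antiproliferative activity, read by MTT assay, with a stated time of 24 h (on this read-out higher numbers stand for weaker inhibition and lower numbers for stronger inhibition), compound 2 gives 66000 nM, the only actual number available, so it cannot yet be ranked against a second number. The sole other result is a limit, held by compound 1: the limit of > 100000 nM in this assay, at which 1 of the 2 values shown sits.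

Compound 3 `C=CCc1cc(-c2cccc(OC)c2)ccc1O` has not yet been measured. It differs from compound 2 as follows: methoxy in place of methylsulfanyl on an aromatic carbon. This places methoxy in place of methylsulfanyl on an aromatic carbon, meta to a large group, and the rest of the structure is unchanged.

For the measured compounds named here, one measured step bears on this, at the same aromatic carbon: an at least 1.5-fold lower number from compound 1 to compound 2 (0.18 log units; that floor lies within the scatter). That step starts from a limit and its floor lies within the scatter, so it gives no firm size or direction. In this assay, no change beyond the scatter is therefore expected, and the expected step is a 1.1-fold higher number from compound 2 to compound 3 (0.03 log units; within the scatter). Compound 3 is estimated at 70000 nM. Its expected range runs from 30000 nM to 100000 nM.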

Compound 3, half-maximal inhibitory concentration: > 100000 nM
Compound 3: only a limit was reported (the forecaster's own chance of this, stated with the estimate: 25%); middle value at least 1.4-fold (0.15 log units) from the limit.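

In this assay compound 3 gives > 100000 nM as a limit of the assay, not a number. Methoxy in place of methylsulfanyl on this aromatic carbon, two groups with equal counts of heavy atoms and hydrogen-bond acceptors, gives an at least 1.5-fold higher number from compound 2 to compound 3 (0.18 log units; that floor lies within the scatter), so compound 2 remains the only compound of the three with an actual number, and the floor of this step does not separate it from compound 3 beyond the scatter. The step between compound 1 and compound 3 cannot be read, and the results now gather at a single limit: the limit of > 100000 nM in this assay, at which 2 of the 3 values shown sit.

The compounds shown leave open whether the number of compound 2 reflects anything specific to methylsulfanyl, since a sulfur-bearing group has been compared here only with groups that end at a limit, and neither limit gives the size of the difference. An amine, a carboxylic acid or a longer chain such as ethylsulfanyl on this aromatic carbon could show whether a second actual number can be obtained in this assay, and whether it would differ from that of compound 2 by more than the scatter.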